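A few compounds are considered here, and "the series" means these few. Any claim that something is new, unique, unknown or untested is made for them only; others in the source may bear on it.

Compound 1 `O=C1NC(=O)/C(=C/C2=Cc3ccccc3OC2)S1` is the starting point, and in a functional assay on MOLT-4 cells (Homo sapiens) for antiproliferative activity, read by MTT assay, with a stated time of 72 h (a lower number here means a stronger inhibitor, a higher number a weaker inhibitor), compound 1 gives 101000 nM. Compound 3 `O=C1NC(=O)/C(=C/C2=Cc3cc(Br)ccc3OC2)S1` carries bromo in place of hydrogen on an aromatic carbon, and compound 3 gives 54700 nM; the step is a 1.8-fold lower number from compound 1 to compound 3 (0.27 log units; within the scatter). Compound 2 `O=C1NC(=O)/C(=C/C2=Cc3ccccc3OC2)N1` has a different core, and the difference between the two cores is not broken down here. In this assay compound 2 gives 21300 nM, the lowest of the three numbers. Compound 4 `O=C1NC(=O)/C(=C/C2=Cc3cc(Br)ccc3OC2)N1` carries bromo in place of hydrogen on an aromatic carbon, the same change seen in compound 3, now made on the core of compound 2. Because the earlier step was a 1.8-fold lower number from compound 1 to compound 3 (0.27 log units; within the scatter), the new step is expected to be a 1.6-fold lower number from compound 2 to compound 4 (0.21 log units; within the scatter), resting on that single precedent. Compound 4 is therefore estimated at 13000 nM, expected between 5000 nM and 35000 nM.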

Compound 4, half-maximal inhibitory concentration: 77500 nM
Estimate against measurement, compound 4: 6.0-fold (0.78 log units) below; measured number outside the range, above it.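

Putting bromo in place of hydrogen on the core of compound 2 gives a 3.6-fold higher number from compound 2 to compound 4 (0.56 log units; beyond the scatter) in this assay. The same change therefore does not carry over unchanged from one core to the other: the same change on two cores in this assay, a 1.8-fold lower number (0.27 log units; within the scatter) from compound 1 to compound 3 and a 3.6-fold higher number (0.56 log units; beyond the scatter) from compound 2 to compound 4, 6.7-fold (0.83 log units) apart, beyond the scatter of two such steps. This comparison rests on a single pair of compounds for each core, with one group at one place in one assay, so it does not show why the two cores differ or whether the gap would hold for any other group.

Going by these compounds, it remains open whether chloro, methoxy or an amine at that same place would behave differently on the two cores. On these data alone, it also remains open whether bromo elsewhere on the aromatic ring would do so.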